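Shortening the Selenium Chain on a Methoxy-Bearing Ring

The source may report more compounds than this note shows. Statements on the series, on what has been measured and on what is new or still open speak of the compounds shown alone.

Compound 1 `COc1ccc(N(C)c2nc(C)nc3ccccc23)cc1C(=O)OCCC[Se]C#N`: 720 nM
Compound 2 `Cc1nc(N(C)c2ccc([Se]C#N)c(Cl)c2)c2ccccc2n1`: 12 nM

In a functional assay on HCT-116 cells (Homo sapiens) for inhibition, read by MTT assay, with a stated time of 48 h (on this read-out lower numbers stand for stronger inhibition and higher numbers for weaker inhibition), compound 1 has the higher of the two numbers at 720 nM, and the gap to compound 2 at 12 nM lies well beyond the scatter. The next compound to be tested is compound 3 `COc1ccc(N(C)c2nc(C)nc3ccccc23)cc1C[Se]C#N`. It comes from compound 1 by a single change: a group of 4 heavy atoms (2 carbon, 1 nitrogen, 1 selenium; no ring) in place of a group of 9 heavy atoms (5 carbon, 1 nitrogen, 2 oxygen, 1 selenium; no ring), on an aromatic carbon. The new group sits on an aromatic carbon of a six-membered aromatic ring of carbon only, ortho to a methoxy group and meta to a large group.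

Within the data shown here, no step between measured compounds that differ in one place is available, so the expectation rests on the two values and on the structural change alone. Compound 2 at 12 nM shows that a much lower number is possible in this small set, although it differs from compound 3 in more than the group changed here. The expected change is a 9.0-fold lower number from compound 1 to compound 3 (0.95 log units; beyond the scatter), in the direction of stronger inhibition and beyond the scatter. The estimated value for compound 3 is 80 nM, with an expected range from 15 nM to 400 nM.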

Compound 3, half-maximal inhibitory concentration: 113 nM
Compound 3: middle estimate off by 1.4-fold (0.15 log units), on the low side; the range from low to high includes it.
By their numbers in this assay, from the lowest: compound 2; then compound 3; then compound 1.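

Placing the group of 4 heavy atoms in place of the group of 9 heavy atoms, on the aromatic carbon ortho to a methoxy group and meta to a large group, gives a 6.4-fold lower number from compound 1 to compound 3 (0.80 log units; beyond the scatter) in this assay. Among these compounds, this is the first direct reading of a change at this position, and it shows that the carbonyl, the two oxygens and the longer carbon chain of the group that leaves are not needed for inhibition of this size, since the selenium and nitrile stay on the ring through a much shorter group. The compounds shown offer no measurement that would explain the step, so it stands here as an observation about structure and read-out alone.

Because the carbonyl, both oxygens and most of the chain leave in one change, the contribution of each part to the step remains unresolved. On these data alone, it also remains open whether a longer chain without the carbonyl, or an amide carrying the same selenium and nitrile end, would give a number closer to that of compound 1 or that of compound 3.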